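Heteroaryl swap at the far end of compound 3

The compounds below may be only part of what the source reports. "The series", "measured", "known", "first", "only" and "open" are said of these compounds alone.

The series keeps one shared core and varies the group attached on an aromatic carbon of the six-membered carbon-only ring, para to a large group. Compound 1 `CCC(C)(C)Cc1c[nH]c(CCc2ccc(-n3ccnn3)cc2)n1` carries 1H-1,2,3-triazol-1-yl there, and in a functional assay on HEK293 cells for agonist activity at Bombesin receptor subtype-3 (Homo sapiens), read by luminescence and calcium flux, with a stated time of 10 min (a lower number here means that less compound is needed, a higher number that more compound is needed for the effect), compound 1 gives 641 nM. Compound 2 `CCC(C)(C)Cc1c[nH]c(CCc2ccc(-c3cccc(C#N)n3)cc2)n1` carries 6-cyanopyridin-2-yl; in this assay compound 2 gives 193 nM. Compound 3 `CCC(C)(C)Cc1c[nH]c(CCc2ccc(-c3csnn3)cc2)n1` carries 1,2,3-thiadiazol-4-yl; in this assay compound 3 gives 538 nM, the second highest of the three numbers. The measured steps are a 3.3-fold lower number from compound 1 to compound 2 (0.52 log units; beyond the scatter), a 1.2-fold lower number from compound 1 to compound 3 (0.08 log units; within the scatter) and a 2.8-fold higher number from compound 2 to compound 3 (0.45 log units; beyond the scatter).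

Compound 4 `CCC(C)(C)Cc1c[nH]c(CCc2ccc(-c3cnsc3)cc2)n1` is the next member. The change: 1,2-thiazol-4-yl in place of 1,2,3-thiadiazol-4-yl on an aromatic carbon. For the measured compounds named here, no measured step exchanges one five-membered ring for another that differs by a single ring atom. The closest guide is a 1.2-fold lower number from compound 1 to compound 3 (0.08 log units; within the scatter), where two five-membered rings with three hetero atoms each gave numbers within the scatter. The larger moves, a 3.3-fold lower number from compound 1 to compound 2 (0.52 log units; beyond the scatter) and a 2.8-fold higher number from compound 2 to compound 3 (0.45 log units; beyond the scatter), both involve the six-membered cyanopyridinyl group and do not bear directly on this swap. In this assay no step beyond the scatter is therefore expected. Compound 4 is estimated at 480 nM, with a range from 220 nM to 1050 nM. The expected step is a 1.1-fold lower number from compound 3 to compound 4 (0.05 log units; within the scatter).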

Compound 4, half-maximal effective concentration: 44 nM
Estimate against measurement, compound 4: 11-fold (1.04 log units) above, outside the stated range (below it).
By their numbers in this assay, from the lowest: compound 4; then compound 2; then compounds 3 and 1 (each within the scatter of the next).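

In this assay, for the compounds shown here, this position turns out to be far more sensitive than the earlier compounds suggested: 1,2-thiazol-4-yl in place of 1,2,3-thiadiazol-4-yl gives a 12-fold lower number from compound 3 to compound 4 (1.09 log units; beyond the scatter) even though both groups are five-membered aromatic rings of 5 heavy atoms, the entering ring holding 3 carbon, 1 nitrogen and 1 sulfur against 2 carbon, 2 nitrogen and 1 sulfur. A six-membered ring carrying a nitrile is also not needed for a low number here, since the same group gives a 4.4-fold lower number from compound 2 to compound 4 (0.64 log units; beyond the scatter) and also a 15-fold lower number from compound 1 to compound 4 (1.16 log units; beyond the scatter), which places compound 4 lowest of the four and leaves five-membered rings at both ends of the series. No measurement at hand accounts for the difference between the two sulfur-containing rings.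

Still open, going by these compounds, is whether the gain depends on how the 1,2-thiazole ring is attached, as 1,2-thiazol-5-yl or 1,2-thiazol-3-yl would test. Also open, on these data alone, is how a thiophene ring, with sulfur as its only ring hetero atom, or a 1,3-thiazole ring would behave at this position.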